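Replacing 3-bromophenyl with 2-fluorophenyl in compound 3

A few compounds are considered here, and "the series" means these few. Any claim that something is new, unique, unknown or untested is made for them only; others in the source may bear on it.

In a functional assay on HepG2 cells (Homo sapiens) for antiproliferative activity, read by MTT assay (on this read-out lower numbers stand for stronger inhibition and higher numbers for weaker inhibition), compound 1 `O=C1N=C(N2CCC[C@H]2C(=O)Nc2ccc3ncnc(Nc4cccc(Cl)c4)c3c2)S/C1=C/c1cccs1` gives 4120 nM, and compound 2 `O=C1N=C(N2CCC[C@H]2C(=O)Nc2ccc3ncnc(Nc4cccc(Cl)c4)c3c2)S/C1=C/c1cccc(Br)c1` gives 21300 nM. Compound 2 therefore holds the higher of the two numbers and is the weaker inhibitor of the pair. Compound 3 `O=C1N=C(N2CCC[C@H]2C(=O)Nc2ccc3ncnc(Nc4cccc(Cl)c4)c3c2)S/C1=C/c1ccccc1F` has 2-fluorophenyl in place of 3-bromophenyl on a double-bonded chain carbon bound to a double-bonded ring carbon. Among the measured compounds shown here, no measured compound carries 2-fluorophenyl, so only one step offers guidance. That step, a 5.2-fold higher number from compound 1 to compound 2 (0.71 log units; beyond the scatter), introduces 3-bromophenyl in place of thiophen-2-yl at the same place, and it is modest but beyond the scatter. Removing 3-bromophenyl is therefore expected to bring a modest move to a lower number in this assay, smaller than that step. The expected change is a 2.4-fold lower number from compound 2 to compound 3 (0.37 log units; beyond the scatter). For compound 3, the estimated value is 9000 nM, with an expected range of 3000 nM to 25000 nM.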

Compound 3, half-maximal inhibitory concentration: 18200 nM
Beside the measured number, compound 3's estimate is 2.0-fold (0.31 log units) below it; low and high end bracket the measured number.
By their numbers in this assay, from the lowest: compound 1; then compounds 3 and 2 (each within the scatter of the next).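

In this assay, the exchange of 3-bromophenyl for 2-fluorophenyl gives a 1.2-fold lower number from compound 2 to compound 3 (0.07 log units; within the scatter), so these two halogen-bearing phenyl groups cannot be told apart at this position, even though they differ in both the halogen and its printed ring position. The second phenyl group also stands clear of thiophen-2-yl, with a 4.4-fold higher number from compound 1 to compound 3 (0.65 log units; beyond the scatter), which shows that the gap first seen with 3-bromophenyl is not confined to that one group. No measurement offered here accounts for this pattern.

Both phenyl groups shown carry a halogen, so it remains open whether the gap from thiophen-2-yl follows the change of ring or the presence of the halogen. Unsubstituted phenyl would address that question, while furan-2-yl would show whether another five-membered ring behaves like thiophen-2-yl.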